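The source may hold more compounds than are shown below. What is called first, only, known or untested is meant among the compounds shown, and "the series" means these compounds.

Compound 1 `Nc1ccccc1NC(=O)c1ccc(CSC(=S)N2CCN(c3cccnc3)CC2)cc1` gives 27.6% in a functional assay on MGC-803 cells (Homo sapiens) for antiproliferative activity, read by CCK-8 assay, with a stated time of 72 h, tested at 2 uM; on this read-out lower numbers stand for a weaker effect and higher numbers for a stronger effect at the one concentration tested.
Compound 2 `Nc1ccccc1NC(=O)c1ccc(CSC(=S)N2CCN(c3ccc(F)cc3)CC2)cc1` gives 18.8% in this assay.
Compound 3 `CN1CCN(C(=S)SCc2ccc(C(=O)Nc3ccccc3N)cc2)CC1` gives 29.6% in this assay.

Going by the values given here, compound 3 has the highest of the three numbers, but the step of a number 2 percentage points higher from compound 1 to compound 3 (within the scatter) is within the scatter, so compound 1 and compound 3 cannot be told apart; only the step of a number 10.8 percentage points higher from compound 2 to compound 3 (beyond the scatter) is beyond the scatter. Compound 4 `Nc1ccccc1NC(=O)c1ccc(CSC(=S)N2CCN(Cc3ccccc3)CC2)cc1` is not yet measured. It differs from compound 3 by phenyl in place of hydrogen on a saturated chain carbon bound to an amine nitrogen in a ring.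

The measured steps all change the group on the ring nitrogen itself: a number 2 percentage points higher from compound 1 to compound 3 (within the scatter), a number 10.8 percentage points higher from compound 2 to compound 3 (beyond the scatter) and a number 8.8 percentage points lower from compound 1 to compound 2 (within the scatter). Among the compounds with values here, none of them puts a phenyl on a chain carbon next to that nitrogen, so no step speaks directly to this change. What the steps do show is that replacing the group on that nitrogen moved the numbers little or modestly. On that basis, the step of a number 3.6 percentage points lower from compound 3 to compound 4 (within the scatter) is expected to be small, possibly a slight drop, and not clearly beyond the scatter. For compound 4 the estimate in this assay is 26%, with a range from 12% to 40%.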

Compound 4, a percentage reported as inhibition, at one concentration (the size of the read-out at that concentration, not a potency): 18.1%
For compound 4 the middle estimate is 7.9 percentage points above the measured one; the measured number falls inside the stated range.
By their numbers in this assay, from the lowest: compounds 4, 2, 1 and 3 (each within the scatter of the next, the first and the last beyond it).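

Going from the methyl of compound 3 to the benzyl of compound 4 is the first change here that adds a phenyl on the saturated chain carbon bound to the ring amine nitrogen, and in this assay it lowers the inhibition read at the one concentration tested (a number 11.5 percentage points lower from compound 3 to compound 4 (beyond the scatter)). Compound 4 cannot be told apart from the two compounds with a ring directly on that nitrogen (a number 0.7 percentage points lower from compound 2 to compound 4 (within the scatter); a number 9.5 percentage points lower from compound 1 to compound 4 (within the scatter)), so the benzyl group gives no gain over either. No supporting measurement is available to explain this step.

An ethyl or a phenylethyl group on the same nitrogen could help separate the contribution of chain length from that of the phenyl ring. A 4-fluorobenzyl group would show whether a ring substituent matters at this position.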